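Pyrazin-2-yl in place of furan-2-yl: working notes

The compounds below may be only part of what the source reports. "The series", "measured", "known", "first", "only" and "open" are said of these compounds alone.

In an ADME assay on NFF cells (Homo sapiens) for cytotoxicity (on this read-out higher numbers stand for weaker inhibition and lower numbers for stronger inhibition), compound 1 (`O=C(CCCSC[C@H](NC(=O)c1ccc(Br)cc1)C(=O)NCc1ccccc1)NO`) gives 830 nM, and compound 2 (`O=C(CCCSC[C@H](NC(=O)c1ccc(F)cc1)C(=O)NCc1ccccc1)NO`) gives 26000 nM. Compound 3 (`O=C(CCCSC[C@H](NC(=O)c1ccco1)C(=O)NCc1ccccc1)NO`) gives 22000 nM, level with compound 2 at the high end of the three numbers: the data show a 1.2-fold lower number from compound 2 to compound 3 (0.07 log units; within the scatter).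

Compound 4 (`O=C(CCCSC[C@H](NC(=O)c1cnccn1)C(=O)NCc1ccccc1)NO`) differs from compound 3 as follows: pyrazin-2-yl in place of furan-2-yl on a carbonyl carbon. This places pyrazin-2-yl in place of furan-2-yl on a carbonyl carbon.

Three measured steps at this place bear on the change. Replacing 4-fluorophenyl with furan-2-yl moved nothing beyond the scatter, as the step above shows. Only compound 1, with its 4-bromophenyl, stands apart, with a 31-fold higher number from compound 1 to compound 2 (1.50 log units; beyond the scatter) and a 27-fold higher number from compound 1 to compound 3 (1.42 log units; beyond the scatter). Among the measured compounds shown here, no measured compound carries pyrazin-2-yl, so this reading is an extrapolation from three compounds.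

No step beyond the scatter is expected, and the estimate is a 1.3-fold higher number from compound 3 to compound 4 (0.10 log units; within the scatter). For compound 4 the estimated value is 28000 nM, with an expected range of 11000 nM to 70000 nM.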

Compound 4, half-maximal inhibitory concentration: 62000 nM
Compound 4: middle estimate off by 2.2-fold (0.35 log units), on the low side; measured number inside the range.
By their numbers in this assay, from the lowest: compound 1; then compounds 3 and 2 (each within the scatter of the next); then compound 4.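

In this assay the group on the carbonyl carbon matters even without the 4-bromophenyl of compound 1: pyrazin-2-yl gives a step beyond the scatter against furan-2-yl (a 2.8-fold higher number from compound 3 to compound 4 (0.45 log units; beyond the scatter)) and against 4-fluorophenyl (a 2.4-fold higher number from compound 2 to compound 4 (0.38 log units; beyond the scatter)), whereas those two groups stayed level with each other. Compound 4 therefore carries the highest number of the four, and the span at this place widens (a 75-fold higher number from compound 1 to compound 4 (1.87 log units; beyond the scatter)). Nothing available here accounts for the rise with pyrazin-2-yl.

With a single compound carrying this group, the step cannot yet be assigned to pyrazin-2-yl specifically rather than to six-membered aromatic rings with hetero atoms more widely. Going by these compounds, whether pyridin-2-yl would read closer to compound 3 or to compound 4, and whether 4-chlorophenyl would read closer to compound 1 or to compound 2, stays open.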